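The source may hold more compounds than are shown below. What is called first, only, known or untested is meant among the compounds shown, and "the series" means these compounds.

The series was examined in a functional assay on PC-3 cells (Homo sapiens) for cytotoxicity, read by MTT assay, with a stated time of 72 h; on this read-out higher numbers stand for weaker inhibition and lower numbers for stronger inhibition. Compound 1 `COc1ccc(-n2ccc(=O)c(C(=O)Nc3ccc(Oc4ccnc5[nH]ccc45)c(F)c3)n2)cc1` gives 46400 nM in this assay. Compound 2 `O=C(Nc1ccc(Oc2ccnc3[nH]ccc23)c(F)c1)c1nn(-c2ccc(Br)cc2)ccc1=O` differs from compound 1 by bromo in place of methoxy on an aromatic carbon; in this assay compound 2 gives 40800 nM, and the change produced a 1.1-fold lower number from compound 1 to compound 2 (0.06 log units; within the scatter). Compound 3 `COc1ccc(-n2ccc(=O)c(C(=O)Nc3ccc(Oc4ccnc5c4ccn5C)cc3)n2)cc1` belongs to a second core, and the difference between the two cores is not broken down here. In this assay compound 3 reaches only a limit, > 60000 nM, a case of the limit of > 60000 nM in this assay, at which 1 of the 3 values shown sits. Compound 4 `Cn1ccc2c(Oc3ccc(NC(=O)c4nn(-c5ccc(Br)cc5)ccc4=O)cc3)ccnc21` carries the same change relative to compound 3 that compound 2 carries relative to compound 1, namely (bromo in place of methoxy on an aromatic carbon), at a place described in identical words. Since the measured version of this change gave a 1.1-fold lower number from compound 1 to compound 2 (0.06 log units; within the scatter), the step to compound 4 is expected to be a step that the limit leaves unreadable from compound 3 to compound 4, which rests on that single earlier step. Compound 4 is therefore estimated at 70000 nM in this assay, with an expected range from 35000 nM to 160000 nM, and a limit rather than a number is a likely outcome.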

Compound 4, half-maximal inhibitory concentration: 23000 nM
The estimate for compound 4 lay 3.0-fold (0.48 log units) above the measured number; measured number below the stated range.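

In this assay, the change from 4-methoxyphenyl to 4-bromophenyl gave an at least 2.6-fold lower number from compound 3 to compound 4 (0.41 log units; beyond the scatter), while on the core of compound 1 the same change gave a 1.1-fold lower number from compound 1 to compound 2 (0.06 log units; within the scatter). Compound 3 is recorded only as a limit, > 60000 nM. The change thus lowered the number beyond the scatter on one core and stayed within it on the other, but this does not show that carrying the change to another core alters its size, and the two pairs give no measured size for the step on the second core: the same change on two cores in this assay, a 1.1-fold lower number (0.06 log units; within the scatter) from compound 1 to compound 2 and an at least 2.6-fold lower number (0.41 log units; beyond the scatter) from compound 3 to compound 4; the limit leaves it open whether they differ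

The compounds shown leave open how a chloro group, an amine or a carboxylic acid in the same place on the six-membered aromatic ring would read out on either core. They also leave open how the two cores compare with each other, and whether the step would hold on any core beyond these two.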